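This account rests on a few compounds, and the source may have more. Where it says the series, first, only, none or still open, it means among the compounds named here.

Of the compounds shown here, two have been measured in an in vitro functional assay on HEK285-7 cells for antagonist activity at prostaglandin D2 receptor 2 (Homo sapiens), read by BRET and beta-arrestin recruitment; on this read-out lower numbers stand for stronger inhibition and higher numbers for weaker inhibition. Compound 1 `Cc1nc(-c2ccc(Cl)cc2)c(CC(=O)O)s1` carries only a hydrogen on the saturated chain carbon bound to an aromatic carbon of the shared core, and in this assay compound 1 gives 41000 nM. Compound 2 `O=C(O)Cc1sc(CSc2ccccc2)nc1-c1ccc(Cl)cc1` carries a phenylsulfanyl group at that position, and in this assay compound 2 gives 450 nM. Among the measured compounds shown here, the single step between them, a 91-fold lower number from compound 1 to compound 2 (1.96 log units; beyond the scatter), shows that what sits on this chain carbon weighs heavily on the read-out, so compound 2 holds the lower of the two numbers by a wide margin.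

Compound 3 `O=C(O)Cc1sc(COc2ccc(Cl)cc2)nc1-c1ccc(Cl)cc1` alters that same position again: 4-chlorophenoxy in place of phenylsulfanyl on a saturated chain carbon bound to an aromatic carbon. The step from compound 1 to compound 2 is the only measured one that touches this position, and it compares a bare hydrogen with a whole aromatic group; nothing measured compares one such group with another. Since compound 3 keeps an aromatic ring tethered to the same chain carbon, the expected step in this assay is a 1.1-fold lower number from compound 2 to compound 3 (0.05 log units; within the scatter), modest and close to the scatter. Compound 3 is accordingly expected to give about 400 nM, within a range from 100 nM to 1600 nM.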

Compound 3, half-maximal inhibitory concentration: 370 nM
Beside the measured number, compound 3's estimate is 1.1-fold (0.03 log units) above it; the measured number falls inside the stated range.
By their numbers in this assay, from the lowest: compounds 3 and 2 (each within the scatter of the next); then compound 1.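

In this assay, placing 4-chlorophenoxy instead of phenylsulfanyl on the saturated chain carbon bound to an aromatic carbon leaves the two compounds within the scatter of each other (a 1.2-fold lower number from compound 2 to compound 3 (0.09 log units; within the scatter)), so this read-out does not tell these two groups apart. The large step away from a bare hydrogen is therefore no longer tied to a single group, since a second aromatic group with oxygen in place of sulfur and an added chlorine also gives one (a 110-fold lower number from compound 1 to compound 3 (2.04 log units; beyond the scatter)). No measurement offered here explains why the two groups give such similar numbers.

Going by these compounds, this exchange changes the sulfur to oxygen and adds a chlorine in one step, so the contribution of each remains unknown; a plain phenoxy group or a 4-chlorophenylsulfanyl group at this position would separate the two. On these data alone, it also remains open whether an aromatic ring is needed at all, which a cyclohexyl group, an amine or a longer saturated chain on the same carbon could test.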